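The source may report more compounds than this note shows. Statements on the series, on what has been measured and on what is new or still open speak of the compounds shown alone.

Measured in a functional assay on A549 cells (Homo sapiens) for inhibition, read by MTT assay, with a stated time of 72 h; a higher number here means a weaker inhibitor, a lower number a stronger inhibitor:
- compound 1 `COc1ccc(/C=C/C(=O)c2c(OC)cc(O)c(CC=C(C)C)c2O)cc1` gives 38000 nM
- compound 2 `COc1ccc(/C=C/C(=O)c2c(O)cc(O)cc2OC)cc1` gives > 50000 nM (a limit)
- compound 3 `COc1ccc(/C=C/C(=O)c2c(O)cc(O)cc2OC)cc1OC` gives > 50000 nM (a limit)

Compound 2 has no exact number in this assay, only the limit > 50000 nM. Compound 3 also has only a limit, and this shared ceiling is the limit of > 50000 nM in this assay, at which 2 of the 3 values shown sit.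

Compound 4 `COc1cc(O)cc(O)c1C(=O)/C=C/c1ccc(Cl)cc1` is still unmeasured. It differs from compound 2 by one change, (chloro in place of methoxy on an aromatic carbon), with chloro in place of methoxy on an aromatic carbon, para to a large group.

Two measured steps offer some guidance, though neither involves chloro. The first, an at least 1.3-fold higher number from compound 1 to compound 2 (0.11 log units; that floor lies within the scatter), concerns the loss of 3-methylbut-2-en-1-yl. The second, a step that the two limits leave unreadable from compound 2 to compound 3, adds a methoxy but gives no usable size. Neither therefore points to a large change, so only a modest move toward a lower number is expected, and compound 4 may well stay at the limit.

The estimated change is an at least 1.2-fold lower number from compound 2 to compound 4 (0.09 log units; that floor lies within the scatter).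

For compound 4 the expected value is 40000 nM, with an estimated range from 15000 nM to 70000 nM.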

Compound 4, half-maximal inhibitory concentration: 18200 nM
Compound 4: the middle estimate sits 2.2-fold (0.34 log units) above what was measured, and the stated range covers the measured number.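

In this assay the place para to a large group proves able to shift the read-out, with chloro in place of methoxy giving an at least 2.7-fold lower number from compound 2 to compound 4 (0.43 log units; beyond the scatter) on the shared core. This is the first step among the compounds shown that lies beyond the scatter, whereas the loss of 3-methylbut-2-en-1-yl stayed within it and the step that adds a methoxy cannot be read. The true size of the new step may be larger, because compound 2 carries only a limit and the step is therefore a floor: the limit of > 50000 nM in this assay, at which 2 of the 4 values shown sit.

Whether the gain comes from chloro arriving or from methoxy leaving stays open, since only one replacement at this place is shown. Plain hydrogen, bromo or an amine at the same place would help separate these two readings.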